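This account rests on a few compounds, and the source may have more. Where it says the series, first, only, none or still open, it means among the compounds named here.

Three compounds share the same long branched chain that ends in a carbonyl group, and each has been measured in a physicochemical assay for lipophilicity; on this read-out lower numbers stand for lower lipophilicity and higher numbers for higher lipophilicity. Compound 1 `C=CCOC(=O)/C=C(C)/C=C/CC(C)CCCC(C)C` gives 6.73. Compound 2 `CCNC(=O)/C=C(C)/C=C/CC(C)CCCC(C)C` gives 5.24, and compound 3 `C=CCNC(=O)/C=C(C)/C=C/CC(C)CCCC(C)C` gives 5.23. Compound 3 is therefore far apart from compound 1, while its number cannot be told apart from that of compound 2. The measured steps show where the spread comes from: a number 1.49 log units lower from compound 1 to compound 2 (beyond the scatter), and a number 1.50 log units lower from compound 1 to compound 3 (beyond the scatter). By contrast, a number 0.01 log units lower from compound 2 to compound 3 (within the scatter), so the choice between an ethyl and an allyl group on the nitrogen leaves the read-out unchanged.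

Compound 4 `CCCC(=O)/C=C(C)/C=C/CC(C)CCCC(C)C` has not yet been measured. It differs from compound 3 by propyl in place of allylamino on a carbonyl carbon, so the nitrogen and its hydrogen-bond donor are gone and a propyl group sits directly on the carbonyl carbon. The two large measured steps both changed the group on this same carbonyl carbon, and the change to compound 4 reaches the same position. The relevant measured evidence is a number 1.50 log units lower from compound 1 to compound 3 (beyond the scatter), which ran downward when the nitrogen came in. Removing that nitrogen again is expected to run the other way, with a large rise in this assay, a number 1.47 log units higher from compound 3 to compound 4 (beyond the scatter). Compound 4 is expected to give 6.7, with a range from 6 to 7.4.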

Compound 4, partition coefficient: 6.81
Estimate against measurement, compound 4: 0.11 log units below; the measured number falls inside the stated range.
By their numbers in this assay, from the lowest: compounds 3 and 2 (each within the scatter of the next); then compounds 1 and 4 (each within the scatter of the next).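

In this assay, among these compounds, the earlier compounds showed only that an ester with allyloxy stands apart from two amides, and the new result shows that a group with no nitrogen and no oxygen on the carbonyl carbon gives the same kind of separation: propyl in place of allylamino gives a number 1.58 log units higher from compound 3 to compound 4 (beyond the scatter) and propyl in place of ethylamino gives a number 1.57 log units higher from compound 2 to compound 4 (beyond the scatter) as a matching step. Allyloxy and propyl cannot be told apart, with a number 0.08 log units higher from compound 1 to compound 4 (within the scatter) as their step, so among these four compounds the two with a nitrogen on the carbonyl carbon sit low and the two without one sit high, and none goes against this split. Nothing available explains why the read-out divides in this way.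

The compounds shown leave open whether the split follows the nitrogen itself or the amide hydrogen, a question that dimethylamino on the same carbonyl carbon, with its nitrogen but no such hydrogen, would address. They also leave open how the number would respond to a longer chain such as hexyl in place of propyl, or to a carboxylic acid at this position.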